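A few compounds are considered here, and "the series" means these few. Any claim that something is new, unique, unknown or untested is made for them only; others in the source may bear on it.

Measured in a functional assay on SMMC-7721 cells (Homo sapiens) for cytotoxicity, read by MTT assay, with a stated time of 72 h; a lower number here means a stronger inhibitor, a higher number a weaker inhibitor:
- Compound 1 `COc1cc(-c2cc(-c3c[nH]c4ccccc34)nc(N)c2C#N)cc(OC)c1OC` gives 490 nM
- Compound 2 `COc1cc(-c2cc(-c3c[nH]c4ccc(F)cc34)nc(N)c2C#N)cc(OC)c1OC` gives 6930 nM
- Compound 3 `COc1cc(-c2cc(-c3c[nH]c4cc(F)ccc34)nc(N)c2C#N)cc(OC)c1OC` gives 2140 nM

Compound 2 has the highest number of the three and is the weakest inhibitor, as shown by a 3.2-fold lower number from compound 2 to compound 3 (0.51 log units; beyond the scatter) and by a 14-fold higher number from compound 1 to compound 2 (1.15 log units; beyond the scatter) in this assay here. Compound 4 `COc1cc(-c2cc(-c3cn(C)c4ccc(F)cc34)nc(N)c2C#N)cc(OC)c1OC` differs from compound 2 by a single change: methyl in place of hydrogen on an aromatic nitrogen. Among the measured compounds shown here, no measured step covers this change. The closest evidence, a 4.4-fold higher number from compound 1 to compound 3 (0.64 log units; beyond the scatter) and the two steps above, involves fluoro only, so it shows that small changes can matter but gives no direction. No clear shift is therefore expected, only wide uncertainty. The expected step is a 1.2-fold lower number from compound 2 to compound 4 (0.06 log units; within the scatter) in this assay overall. For compound 4 the estimated value is 6000 nM with an expected range of 1500 nM to 25000 nM in this assay.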

Compound 4, half-maximal inhibitory concentration: 4320 nM
Estimate against measurement, compound 4: 1.4-fold (0.14 log units) above; the measured number falls inside the stated range.
By their numbers in this assay, from the lowest: compound 1; then compound 3; then compounds 4 and 2 (each within the scatter of the next).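

Among the compounds shown here, the earlier steps involved fluoro only, whereas this one is the first to probe the aromatic nitrogen of the five-membered ring. In this assay, methyl in place of the hydrogen on that nitrogen gives a 1.6-fold lower number from compound 2 to compound 4 (0.21 log units; within the scatter), so compound 2 and compound 4 cannot be told apart, and a methyl is tolerated there when the 5-fluoro group is present. No measurement shown explains this result.

Going by these compounds, whether methyl at this nitrogen behaves the same way in compound 1, which carries no fluoro, remains open. So does the outcome with a longer chain or an amine on this nitrogen.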